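The source may report more compounds than this note shows. Statements on the series, on what has been measured and on what is new or still open speak of the compounds shown alone.

Going by the values given here, compound 2 `COc1ccc(C(=O)/C=C/c2cccc([N+](=O)[O-])c2)c2c1C=CC(C)(C)O2` reads 5870 nM in a functional assay on K562 cells (Homo sapiens) for antiproliferative activity, read by MTT assay, with a stated time of 24 h (a higher number here means a weaker inhibitor, a lower number a stronger inhibitor), and compound 1 `COc1ccc(C(=O)/C=C/c2ccc(N(C)C)cc2)c2c1C=CC(C)(C)O2` reads 3500 nM in the same test, and these are the only two numbers so far. With a 1.7-fold higher number from compound 1 to compound 2 (0.22 log units; within the scatter) between them, the two cannot be told apart. The next compound, compound 3 `COc1ccc(C(=O)/C=C/c2ccc(Cl)cc2)c2c1C=CC(C)(C)O2`, carries 4-chlorophenyl in place of 3-nitrophenyl on a double-bonded chain carbon bound to a double-bonded chain carbon and keeps the rest of the structure. Among the compounds with values here, the only measured change at this place, 4-(dimethylamino)phenyl to 3-nitrophenyl, gave a 1.7-fold higher number from compound 1 to compound 2 (0.22 log units; within the scatter) and so offers no reason to expect a step beyond the scatter in this assay in either direction. A single step is thin evidence, so the range stays wide. The estimated step is a 1.3-fold lower number from compound 2 to compound 3 (0.12 log units; within the scatter) at its middle. In this assay the estimated value for compound 3 is 4500 nM with a wide expected range (1800 nM to 11000 nM).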

Compound 3, half-maximal inhibitory concentration: > 10000 nM
Compound 3: only a limit was reported (the forecaster's own chance of this, stated with the estimate: 3%); at least 2.2-fold (0.34 log units) between middle value and limit.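

In this assay compound 3 gives only a limit, > 10000 nM, and not a number. Going by these compounds alone, replacing 3-nitrophenyl with 4-chlorophenyl gives a floor that still cannot separate the two compounds (an at least 1.7-fold higher number from compound 2 to compound 3 (0.23 log units; that floor lies within the scatter)), whereas chloro in place of dimethylamino on an aromatic carbon gives the first step at this position that lies beyond the scatter (an at least 2.8-fold higher number from compound 1 to compound 3 (0.45 log units; beyond the scatter)), so the group carried here can change the reading. The size of that step is known only as a floor, with its true value hidden by this reading: the limit of > 10000 nM in this assay, at which 1 of the 3 values shown sits.

Still open, going by these compounds, is how a ring carrying a simple amine or a carboxylic acid at this place would read. On these data alone, it is also open whether a plain phenyl ring would sit closer to compound 1 or to compound 3.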